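Swapping the Aryl Group on the Triazole Nitrogen

A few compounds are considered here, and "the series" means these few. Any claim that something is new, unique, unknown or untested is made for them only; others in the source may bear on it.

Two close relatives of one natural-product-like core have been tested in a functional assay on HeLa cells (Homo sapiens) for cytotoxicity, read by MTT assay, with a stated time of 48 h; on this read-out higher numbers stand for weaker inhibition and lower numbers for stronger inhibition. Compound 1 `COc1cccc(-n2cc(COc3ccc(/C=C4\C[C@]5(C)[C@@H](CC/C=C(\C)CC/C=C(\C)CCC=C(C)C)[C@](C)(O)CC[C@H]5C(C)(C)C4=O)cc3)nn2)c1` carries a 3-methoxyphenyl on the aromatic nitrogen of the triazole ring, and in this assay compound 1 gives 16200 nM. Compound 2 `CC(C)=CCC/C(C)=C/CC/C(C)=C/CC[C@@H]1[C@@]2(C)C/C(=C\c3ccc(OCc4cn(-c5ccccc5C#N)nn4)cc3)C(=O)C(C)(C)[C@@H]2CC[C@@]1(C)O` differs only in bearing a 2-cyanophenyl at that position, and in this assay compound 2 gives 100000 nM. Within the data shown here, that single exchange produced a 6.2-fold higher number from compound 1 to compound 2 (0.79 log units; beyond the scatter), so compound 2 stands as the highest of the two numbers measured, with compound 1 as its only neighbour.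

Compound 3 `CC(C)=CCC/C(C)=C/CC/C(C)=C/CC[C@@H]1[C@@]2(C)C/C(=C\c3ccc(OCc4cn(-c5cccc([N+](=O)[O-])c5)nn4)cc3)C(=O)C(C)(C)[C@@H]2CC[C@@]1(C)O` is the next variation on the same position: 3-nitrophenyl in place of 2-cyanophenyl on an aromatic nitrogen. Among the measured compounds shown here, the only step measured so far concerns this same aromatic nitrogen, and it shows that changing the aryl group there can move the number well beyond the scatter. Because of a 6.2-fold higher number from compound 1 to compound 2 (0.79 log units; beyond the scatter), the step from compound 2 to compound 3 is expected to be of comparable size and to run downward, toward the number seen for compound 1, giving an estimated 2.5-fold lower number from compound 2 to compound 3 (0.40 log units; beyond the scatter). Compound 3 is therefore expected to give about 40000 nM, within a range from 12000 nM to 100000 nM.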

Compound 3, half-maximal inhibitory concentration: 32900 nM
Compound 3: middle estimate off by 1.2-fold (0.08 log units), on the high side; measured number inside the range.
By their numbers in this assay, from the lowest: compound 1; then compound 3; then compound 2.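

In this assay, a second exchange on the aromatic nitrogen gives a 3.0-fold lower number from compound 2 to compound 3 (0.48 log units; beyond the scatter), so 2-cyanophenyl is not the only replacement for 3-methoxyphenyl to be tested here, and 3-nitrophenyl lands between the two earlier numbers. The comparison of 3-methoxyphenyl with 3-nitrophenyl is the cleanest so far, as the ring stays the same and the group carries the same number in its name; nitro in place of methoxy on an aromatic carbon gives a 2.0-fold higher number from compound 1 to compound 3 (0.31 log units; beyond the scatter), the smallest of the steps at this position. The exchange of 2-cyanophenyl for 3-nitrophenyl, by contrast, alters both the group and the number in its name, so that step alone cannot separate the two changes.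

No measurement bearing on the reason for these differences is available. The compounds shown leave open how a plain phenyl ring would compare, and how a 3-cyanophenyl or a 2-nitrophenyl, or a phenyl ring carrying an amine or a carboxylic acid, would read in this assay at this same nitrogen.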